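The compounds below may be only part of what the source reports. "The series", "measured", "known", "first", "only" and "open" are said of these compounds alone.

Of the compounds shown here, three sharing one core have been measured so far. Compound 1 `COc1cc(OC)c(OC)cc1/C=C/COC(=O)/C=C/c1ccccc1C(F)(F)F` gives 100% in a functional assay on the whole organism (strain Kunming) with Mus musculus as the target, with a stated time of 0.5 h, at a dose of 300 mg/kg by the intraperitoneal route; on this read-out lower numbers stand for a stronger effect and higher numbers for a weaker effect at the one dose given. Compound 2 `COc1cc(OC)c(OC)cc1/C=C/COC(=O)/C=C/c1cccc(Br)c1` gives 100% in this assay, and compound 3 `COc1ccc(/C=C/C(=O)OC/C=C/c2cc(OC)c(OC)cc2OC)cc1` gives 100% in this assay. The substituted phenyl group at the far end of the chain differs among them, yet the read-out does not move: no change at the digits printed from compound 1 to compound 2 (within the scatter), no change at the digits printed from compound 1 to compound 3 (within the scatter), and no change at the digits printed from compound 2 to compound 3 (within the scatter). On the numbers shown, compound 3 stands level with compounds 1 and 2.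

Compound 4 `COc1cc(OC)c(OC)cc1/C=C/COC(=O)/C=C/c1ccc(Cl)cc1` has not yet been measured in this assay. It differs from compound 3 in one place: chloro in place of methoxy on an aromatic carbon, which cut one bond further out reads 4-methoxyphenyl to 4-chlorophenyl. The measured steps that bear on this are the three exchanges of that phenyl group, each within the scatter. Since no exchange there has shifted the value, the expected step is no change at the digits printed from compound 3 to compound 4 (within the scatter), none beyond the scatter. Compound 4 is therefore estimated at 100%, ranging from 85% to 100%.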

Compound 4, a percentage reported as activity, at one dose (the size of the read-out at that dose, not a potency): 100%
Estimate against measurement, compound 4: no gap at the digits printed; measured number inside the range.
By their numbers in this assay, from the lowest: compounds 1, 2, 3 and 4 (each within the scatter of the next).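

Compared with the earlier exchanges, which also moved the substituent around the phenyl group, this change keeps the place on the ring fixed, para to a large group, and alters only the substituent: chloro in place of methoxy gives no change at the digits printed from compound 3 to compound 4 (within the scatter) in this assay. The other two comparisons agree, with no change at the digits printed from compound 2 to compound 4 (within the scatter) and no change at the digits printed from compound 1 to compound 4 (within the scatter), so four different substituted phenyl groups now give the same read-out at this one dose. No measurement shown here accounts for this flat result.

From the compounds shown here alone, what remains open is whether any group at this position can move the read-out, such as an amine or a carboxylic acid on the phenyl group. Also unresolved is whether an amide in place of the ester would do so.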